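The compounds below may be only part of what the source reports. "The series", "measured", "known", "first", "only" and "open" are said of these compounds alone.

Measured so far:
- compound 1 `Cc1ccc(CSc2cc(Cl)c(C)cc2S(=O)(=O)/N=C(\N)n2nc(C)cc2-c2ccccc2)cc1`: 89000 nM
- compound 2 `Cc1cc(S(=O)(=O)/N=C(\N)n2nccc2-c2ccccc2)c(SCc2ccccc2)cc1Cl`: 20000 nM

In a functional assay on MCF7 cells (Homo sapiens) for cytotoxicity, read by MTT assay, with a stated time of 72 h (on this read-out lower numbers stand for stronger inhibition and higher numbers for weaker inhibition), compound 1 gives 89000 nM, the higher of the two numbers in hand; compound 2 gives 20000 nM in this assay, and the gap between the two values is beyond the usual scatter. Compound 3 `Cc1cccc(CSc2cc(Cl)c(C)cc2S(=O)(=O)/N=C(\N)n2nc(C)cc2-c2ccccc2)c1` has not yet been measured. It differs from compound 1 only by 3-methylphenyl in place of 4-methylphenyl on a saturated chain carbon bound to a sulfur; the two share every atom and the whole core, with the methyl on that ring simply moved. Within the data shown here, no measured pair in this set shows what such a move does, so the expectation rests on the size of the change alone. Compound 3 is expected to change little, with a step of a 1.1-fold lower number from compound 1 to compound 3 (0.05 log units; within the scatter) from compound 1 that should stay within the scatter, in no firm direction. Compound 3 is estimated at 80000 nM in this assay, with a range from 30000 nM to 250000 nM.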

Compound 3, half-maximal inhibitory concentration: 105000 nM
For compound 3 the middle estimate is 1.3-fold (0.12 log units) below the measured one; the measured number falls inside the stated range.
By their numbers in this assay, from the lowest: compound 2; then compounds 1 and 3 (each within the scatter of the next).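

In this assay, 3-methylphenyl in place of 4-methylphenyl on a saturated chain carbon bound to a sulfur gives a 1.2-fold higher number from compound 1 to compound 3 (0.07 log units; within the scatter). Among these compounds, this is the first measured change at this position, and it shows that the read-out does not tell these two placements of the methyl apart, so compound 1 and compound 3 stand together on this scale. Nothing measured here offers an explanation for this result.

The step says nothing about whether a methoxy group, an amine or a carboxylic acid in place of that methyl would move the number beyond the scatter. It also leaves open what a longer chain at the saturated chain carbon bound to a sulfur would do.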